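This account rests on a few compounds, and the source may have more. Where it says the series, first, only, none or still open, it means among the compounds named here.

Measured compounds:
compound 1, `CCCCCCCNC(=O)[C@H]1OC(n2cnc3c(N)ncnc32)[C@H](O)[C@@H]1O`: 20 nM
compound 2, `CCCCCCCCCNC(=O)[C@H]1OC(n2cnc3c(N)ncnc32)[C@H](O)[C@@H]1O`: 31 nM
compound 3, `CC(C)(C)NC(=O)[C@H]1O[C@@H](n2cnc3c(N)ncnc32)[C@H](O)[C@@H]1O`: 6850 nM

In an assay on cell membranes for binding affinity to 2-oxoglutarate receptor 1 (Rattus norvegicus), read by radioligand binding (a lower number here means a stronger inhibitor, a higher number a weaker inhibitor), compound 2 gives the second highest of the three numbers. Its nearest neighbour is compound 1, and the step of a 1.6-fold higher number from compound 1 to compound 2 (0.19 log units; within the scatter) lies within the scatter, so the two cannot be ordered. Among the measured compounds shown here, the furthest is compound 3, whose value in this assay is far higher than that of compound 2; the two structures differ in more than one place, so no single step is drawn between them.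

Compound 4, `CC(=O)NCCNC(=O)[C@H]1OC(n2cnc3c(N)ncnc32)[C@H](O)[C@@H]1O`, has not been measured. It differs from compound 2 by acetamido in place of heptyl on a saturated chain carbon, two bonds along the chain from an amide-type nitrogen; cut one bond further out, the same difference reads nonyl to 2-acetamidoethyl. For the measured compounds named here, the only single-place step measured, from compound 1 to compound 2, extends a saturated chain and stays within the scatter, so it says nothing about trading the chain for acetamido. Compound 3, with its short substituent on the amide nitrogen, shows that this series tolerates a much higher number when the long chain is absent. The expectation for compound 4 in this assay is therefore a clearly higher number, a step of about a 32-fold higher number from compound 2 to compound 4 (1.51 log units; beyond the scatter), with wide uncertainty. Compound 4 is estimated at 1000 nM, between 150 nM and 6000 nM.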

Compound 4, inhibition constant: 46 nM
Estimate against measurement, compound 4: 22-fold (1.34 log units) above; measured number outside the range, below it.
By their numbers in this assay, from the lowest: compounds 1, 2 and 4 (each within the scatter of the next, the first and the last beyond it); then compound 3.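

In this assay, the step of a 1.5-fold higher number from compound 2 to compound 4 (0.17 log units; within the scatter) lies within the scatter, so acetamido in place of heptyl on a saturated chain carbon, two bonds along the chain from an amide-type nitrogen, leaves the two compounds unordered, and a long all-carbon chain is not needed at this position for a number of this size. The second reading, a 2.3-fold higher number from compound 1 to compound 4 (0.36 log units; beyond the scatter), for acetamido in place of pentyl at the same place, is beyond the scatter but modest, so the exchange carries at most a small cost against the shorter of the two chains. No available evidence bears on the reason for this tolerance.

Still open, from the compounds shown here alone, is which part of the acetamido group matters, since an amine, a carboxylic acid or a plain butyl chain at the same place would each separate the chain length from the carbonyl and the amide hydrogen. Also open, going by these compounds, is whether a longer chain ending in acetamido keeps a number in this range in this assay.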